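The compounds below may be only part of what the source reports. "The series", "measured", "known", "first", "only" and "open" are said of these compounds alone.

Compound 1 `Cc1sc2c(Nc3ccc(C#N)cc3)cccc2c1C`: 49.6%
Compound 2 `Cc1sc2c(Nc3cccnc3)cccc2c1C`: 48.1%

In a functional assay for inhibition, with a stated time of 2 h, tested at 0.0156 g/L (on this read-out higher numbers stand for more inhibition at the one concentration tested (going by the name of the read-out) and lower numbers for less inhibition), compound 2 gives 48.1%, the lower of the two numbers, while compound 1 gives 49.6%; the gap between them lies within the scatter, so the two numbers count as level. Compound 3 `Cc1sc2c(Nc3ccccn3)cccc2c1C` has not yet been measured. It differs from compound 2 by pyridin-2-yl in place of pyridin-3-yl on a nitrogen on an aromatic ring. Going by the values given here, no measured pair shows such a change, so the size of the step in this assay is unknown; the expected step from compound 2 to compound 3 is a number 3.1 percentage points lower from compound 2 to compound 3 (within the scatter), none beyond the scatter. Compound 3 is therefore estimated at 45%, between 25% and 65%.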

Compound 3, a percentage reported as inhibition, at one concentration (the size of the read-out at that concentration, not a potency): 40.7%
Compound 3: middle estimate off by 4.3 percentage points, on the high side; the range from low to high includes it.
By their numbers in this assay, from the lowest: compounds 3, 2 and 1 (each within the scatter of the next).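

Swapping one pyridine for the other on this nitrogen keeps the same atoms and joins them differently, and in this assay the swap gives a number 7.4 percentage points lower from compound 2 to compound 3 (within the scatter) as the first measured step at this place. That step lies within the scatter, so this change shows no firm effect and compound 2 and compound 3 count as level. No measurement here offers an explanation for the numbers. Still open, going by these compounds, is whether pyridin-4-yl would read differently from these two pyridines. Also open, on these data alone, is whether an amine or a carboxylic acid on the ring would move the number beyond the scatter.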